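Cyclohexyl to thian-4-yl on the terminal amine arm

The source may hold more compounds than are shown below. What is called first, only, known or untested is meant among the compounds shown, and "the series" means these compounds.

Two compounds have numbers in a functional assay on cells for antagonist activity at C-X-C chemokine receptor type 4 (Homo sapiens), read by fluorescence and calcium flux, with stated times of 25 min and 90 s; on this read-out higher numbers stand for weaker inhibition and lower numbers for stronger inhibition. Compound 1 `c1ccc(CN(CCCCN(C[C@H]2Cc3ccccc3CN2)[C@H]2CCCc3cccnc32)Cc2ccccn2)nc1` gives 664 nM in this assay. Compound 2 `c1ccc2c(c1)CN[C@@H](CN(CCCCNCC1CCCCC1)[C@H]1CCCc3cccnc31)C2` gives 158 nM in this assay, the lower of the two numbers, and the gap to compound 1 lies beyond the usual scatter. Compound 3 `c1ccc2c(c1)CN[C@@H](CN(CCCCNCC1CCSCC1)[C@H]1CCCc3cccnc31)C2` is not yet measured in this assay. The change from compound 2 to compound 3 is thian-4-yl in place of cyclohexyl on a saturated chain carbon bound to an amine nitrogen. Among the compounds with values here, no measured pair of compounds in this set differs by this kind of swap, so the expectation rests on compound 2 alone. The step from compound 2 to compound 3 is expected to be small, a 1.3-fold higher number from compound 2 to compound 3 (0.12 log units; within the scatter), with no change beyond the scatter, if anything toward a slightly higher number. Compound 3 is estimated at 210 nM in this assay, with a range from 80 nM to 550 nM.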

Compound 3, half-maximal inhibitory concentration: 69.6 nM
Estimate against measurement, compound 3: 3.0-fold (0.48 log units) above; measured number outside the range, below it.
By their numbers in this assay, from the lowest: compound 3; then compound 2; then compound 1.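

On a saturated chain carbon bound to an amine nitrogen, thian-4-yl in place of cyclohexyl in this assay gives a 2.3-fold lower number from compound 2 to compound 3 (0.36 log units; beyond the scatter), a modest step toward stronger inhibition. The earlier compounds shown here gave no reading of this change; it now shows that a ring of carbon only is not required here, and that a sulfur atom in the six-membered ring, with the heavy-atom count unchanged, goes with the lower number. No measurement shown here accounts for the step.

From the compounds shown here alone, whether the step belongs to sulfur in particular or to any ring hetero atom stays open, and tetrahydropyran-4-yl, piperidin-4-yl or the sulfone of the thian-4-yl ring in the same place would help to separate these readings. Going by these compounds, with a single step of this kind, it also remains unknown whether the swap carries over to other compounds.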